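A few compounds are considered here, and "the series" means these few. Any claim that something is new, unique, unknown or untested is made for them only; others in the source may bear on it.

Compound 1 `CC(C)N(Cc1cccc(OCCCCCC(=O)O)c1)C(=O)c1ccc(-c2cccc(Oc3ccccc3)c2)cc1` and compound 2 `CCOC(=O)CCCCCOc1cccc(CN(C(=O)c2ccc(-c3cccnc3)cc2)C(C)C)c1` share one core, and compound 3 `CCOC(=O)CCCCCOc1cccc(CN(C(=O)c2ccc(-c3cccc(OCC)c3)cc2)C(C)C)c1` continues from compound 2. In an ADME assay on Raji cells (Homo sapiens) for cytotoxicity, read by CellTiter-Glo and resazurin assay, with a stated time of 72 h (a lower number here means that less compound is needed, a higher number that more compound is needed for the effect), compound 1 gives only a limit of the assay, > 18700 nM. In this assay compound 2 also gives only a limit, > 26000 nM, so no exact number for it is known. Compound 3 differs from compound 2 by 3-ethoxyphenyl in place of pyridin-3-yl on an aromatic carbon. Going by the values given here, no measured step of this kind stands among the compounds, so no movement beyond the usual scatter is expected in this assay. The expected step is a step that the limit leaves unreadable from compound 2 to compound 3. Compound 3 is therefore expected to give about 30000 nM, somewhere between 10000 nM and 100000 nM.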

Compound 3, half-maximal effective concentration: > 22300 nM
Compound 3 ended at the assay's limit (the forecaster's own chance of this, stated with the estimate: 75%); the middle value does not contradict the limit.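

Going by these compounds alone, compound 2 and compound 3 each give only a limit in this assay, so no step between them can be read. Going by these compounds, whether 3-ethoxyphenyl in place of pyridin-3-yl shifts the concentration needed for the effect stays open.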